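The compounds below may be only part of what the source reports. "The series", "measured", "known", "first", "only" and "open" are said of these compounds alone.

Compound 3 `COC(=O)C1=C(C)NC(=O)N(C(=O)NCCCN2CCN(c3ccc(Cl)cc3)CC2)C1c1ccc(F)c(F)c1` carries a 4-chlorophenyl on an amine nitrogen in a ring, and in an assay on liver for binding affinity to Alpha-1A adrenergic receptor (Homo sapiens), using microsomes (on this read-out higher numbers stand for weaker inhibition and lower numbers for stronger inhibition), compound 3 gives 0.8 nM. Among the three compounds measured so far it holds the second highest number. Its nearest neighbour is compound 2 `CCC1=C(C(N)=O)C(c2ccc(F)cc2F)N(C(=O)NCCCN2CCN(c3ccccc3C(N)=O)CC2)C(=O)N1`, which in this assay gives 1.3 nM, a gap that lies within the scatter of repeated measurements. Within the data shown here, the furthest is compound 1 `COC(=O)C1=C(C)NC(=O)N(C(=O)NCCCN2CCN(c3ccccc3OC)CC2)C1c1ccc(F)c(F)c1`, which in this assay gives 0.1 nM; the only single-point step recorded, an 8.0-fold higher number from compound 1 to compound 3 (0.90 log units; beyond the scatter), separates these two, and it lies beyond the scatter.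

Compound 4 `COC(=O)C1=C(C)NC(=O)N(C(=O)NCCCN2CCN(c3cccc(Cl)c3)CC2)C1c1ccc(F)c(F)c1` differs from compound 3 by 3-chlorophenyl in place of 4-chlorophenyl on an amine nitrogen in a ring. Among the measured compounds shown here, no measured pair shows this particular change: the one recorded step swaps a 2-methoxyphenyl for a 4-chlorophenyl, which is a different exchange, so it offers no direct guide to moving the chlorine from one position of the phenyl to another. For the measured compounds named here, with no step of this kind to lean on, the change is expected to produce no step beyond the scatter in this assay, though a shift in either direction cannot be ruled out. Compound 4 is therefore estimated at 0.8 nM, within a range of 0.3 nM to 2.5 nM, which means an expected step of no change at the digits printed from compound 3 to compound 4 (within the scatter).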

Compound 4, inhibition constant: 0.7 nM
Compound 4: the middle estimate sits 1.1-fold (0.06 log units) above what was measured; the range from low to high includes it.
By their numbers in this assay, from the lowest: compound 1; then compounds 4, 3 and 2 (each within the scatter of the next).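

Exchanging 4-chlorophenyl for 3-chlorophenyl on the amine nitrogen in a ring gives a 1.1-fold lower number from compound 3 to compound 4 (0.06 log units; within the scatter) in this assay and so shows that, for this pair, the two chlorine positions on the phenyl cannot be told apart at this place. The exchange of 2-methoxyphenyl for 3-chlorophenyl gives a 7.0-fold higher number from compound 1 to compound 4 (0.85 log units; beyond the scatter) and joins an 8.0-fold higher number from compound 1 to compound 3 (0.90 log units; beyond the scatter) as a second step beyond the scatter, so the gap from compound 1 now holds for two chlorophenyl compounds rather than one. No measured information that could explain either result is available.

Going by these compounds, it remains open whether the low number of compound 1 goes with the methoxy group or with its place on the phenyl, as compound 1 differs from compounds 3 and 4 in both at once; a 2-chlorophenyl or a 3-methoxyphenyl on the same nitrogen would separate the two. On these data alone, it is also open whether the match between compounds 3 and 4 extends to other groups on the phenyl, such as a methyl or a trifluoromethyl.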